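The source may hold more compounds than are shown below. What is called first, only, known or untested is meant among the compounds shown, and "the series" means these compounds.

The measured compounds:

compound 1, `Nc1nc(N2CCN(C(=O)COc3ccccc3)CC2)c2ccsc2n1`, giving 780 nM
compound 2, `Nc1nc(N2CCN(C(=O)COc3ccc(Br)cc3)CC2)c2ccsc2n1`, giving 320 nM

In a functional assay on cells (Lymphocyte) (on this read-out higher numbers stand for weaker inhibition and lower numbers for stronger inhibition), compound 1 gives 780 nM and compound 2 gives 320 nM. Among the compounds with values here, the only measured step, a 2.4-fold lower number from compound 1 to compound 2 (0.39 log units; beyond the scatter), is a bromo in place of hydrogen on an aromatic carbon. Compound 2 therefore stands lowest of the two numbers, with compound 1 as its nearest neighbour.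

Compound 3, `Cc1cccc(OCC(=O)N2CCN(c3nc(N)nc4sccc34)CC2)c1`, differs from compound 2 by 3-methylphenyl in place of 4-bromophenyl on an oxygen on a saturated carbon. The step from compound 1 to compound 2 bears on this change only in part: it shows what the bromine on the phenyl contributed, and that bromine now leaves. Within the data shown here, no measured pair shows what 3-methylphenyl does in place of phenyl. The most cautious expectation is that the number returns toward the value of compound 1, since the gain seen in a 2.4-fold lower number from compound 1 to compound 2 (0.39 log units; beyond the scatter) is no longer supported, while the 3-methylphenyl may or may not recover part of it. Compound 3 is expected to give 550 nM, a step of a 1.7-fold higher number from compound 2 to compound 3 (0.24 log units; within the scatter), within a range of 250 nM to 1200 nM.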

Compound 3, half-maximal inhibitory concentration: 210 nM
The estimate for compound 3 lay 2.6-fold (0.42 log units) above the measured number, and the stated range ends above it.
By their numbers in this assay, from the lowest: compounds 3 and 2 (each within the scatter of the next); then compound 1.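

In this assay, the change to 3-methylphenyl in place of 4-bromophenyl on an oxygen on a saturated carbon gives a 1.5-fold lower number from compound 2 to compound 3 (0.18 log units; within the scatter), so on this read-out the two groups cannot be told apart. Putting 3-methylphenyl where the plain phenyl stood gives a 3.7-fold lower number from compound 1 to compound 3 (0.57 log units; beyond the scatter), which shows that the step away from the plain phenyl of compound 1 does not depend on bromine: a methyl group, at a different place on the ring, also gives a step beyond the scatter. Nothing measured here explains why these two substituted phenyl groups read alike.

The compounds shown leave open whether the identity of the substituent or its place on the ring carries the step, as bromo and methyl differ in both here. They also leave open how a chloro, a methoxy or an amine on the phenyl would read, and whether a benzyl in place of the phenyl on this oxygen would hold the number.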